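Swapping a Phenyl Group on a Shared Core

A few compounds are considered here, and "the series" means these few. Any claim that something is new, unique, unknown or untested is made for them only; others in the source may bear on it.

Of the compounds shown here, two built on the same core have been measured in a functional assay on ACHN cells (Homo sapiens) for inhibition, read by sulforhodamine B assay, with a stated time of 48 h, tested at 10 uM; a higher number here means more inhibition at the concentration tested (going by the name of the read-out), a lower number less inhibition. Compound 1, `O=Cc1ccc(-c2cn3ccnc3c(-c3ccc4ncn(C5CCCCC5)c4c3)n2)cc1`, gives 11.6%. Compound 2, `COc1ccccc1-c1cn2ccnc2c(-c2ccc3ncn(C4CCCCC4)c3c2)n1`, carries a 2-methoxyphenyl in place of the 4-formylphenyl of compound 1; in the same assay compound 2 gives 4.48%. Among the measured compounds shown here, the one measured step, a number 7.1 percentage points lower from compound 1 to compound 2 (within the scatter), lies within the scatter. Of the two numbers shown, compound 1 has the larger, but because the gap to compound 2 is a number 7.1 percentage points lower from compound 1 to compound 2 (within the scatter) the two cannot be ranked, and both sit low.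

Compound 3, `FC(F)(F)c1cccc(-c2cn3ccnc3c(-c3ccc4ncn(C5CCCCC5)c4c3)n2)c1`, has not been measured. Relative to compound 1 it carries 3-(trifluoromethyl)phenyl in place of 4-formylphenyl on an aromatic carbon. For the measured compounds named here, the only step that bears on this change is the earlier exchange of the same 4-formylphenyl for a different phenyl group, a number 7.1 percentage points lower from compound 1 to compound 2 (within the scatter), which did not move the number beyond the scatter. A second exchange at the same position is therefore expected to behave alike, with no step beyond the scatter and the number staying in the low range of the measured compounds. Compound 3 is expected to give 8%, between -5% and 22%. This estimate means a step of a number 3.6 percentage points lower from compound 1 to compound 3 (within the scatter), which is expected to stay within the scatter.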

Compound 3, a percentage reported as inhibition, at one concentration (the size of the read-out at that concentration, not a potency): 0.3%
Estimate against measurement, compound 3: 7.7 percentage points above; the range from low to high includes it.
By their numbers in this assay, from the lowest: compounds 3, 2 and 1 (each within the scatter of the next, the first and the last beyond it).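

The exchange at this aromatic carbon now produces a step that can be read: with 3-(trifluoromethyl)phenyl in place of 4-formylphenyl, this assay shows a number 11.3 percentage points lower from compound 1 to compound 3 (beyond the scatter), so the group here can move the number, though only modestly, which the earlier exchange could not show. The exchange of 2-methoxyphenyl for 3-(trifluoromethyl)phenyl gives a number 4.2 percentage points lower from compound 2 to compound 3 (within the scatter), so compound 2 and compound 3 cannot be ranked, and compound 2 cannot be separated from either end of the series. No measurement in hand gives a reason for the step from the formyl-bearing group to the trifluoromethyl-bearing one.

Both the substituent and its place on the phenyl ring differ between compound 1 and compound 3, so these compounds cannot say which of the two changes matters, and an unsubstituted phenyl would be a useful reference point. On these data alone, it also remains open whether a quite different group at this carbon, such as an amine or a carboxylic acid on the phenyl ring, would lift the number out of the low range that all three compounds share.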